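Swapping the Amide Amine in a Transferase Inhibitor Pair

This account rests on a few compounds, and the source may have more. Where it says the series, first, only, none or still open, it means among the compounds named here.

Measured so far:
Compound 1 `CCOC(=O)C(=O)CC(=O)/C=C/c1cn(CC(=O)N2CCOCC2)c2ccccc12`: in an assay on isolated protein for inhibition of DNA nucleotidylexotransferase (Homo sapiens), read by scintillation counting, with a stated time of 10 min (on this read-out lower numbers stand for stronger inhibition and higher numbers for weaker inhibition), compound 1 gives > 40 uM, which is a limit of the assay and not a number.
Compound 2 `CN(C)C(=O)Cn1cc(/C=C/C(=O)CC(=O)C(=O)O)c2ccccc21`: in this assay compound 2 gives 8.9 uM.

Among the compounds with values here, compound 2 thus stands as the only measured number in this pair; the other value is a limit. The pair of compound 1 and compound 2 differ in two places, so their values are not read as a single step, and the limit of > 40 uM in this assay, at which 1 of the 2 values shown sits, marks where compound 1 sits.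

The new compound 3 `O=C(/C=C/c1cn(CC(=O)N2CCOCC2)c2ccccc12)CC(=O)C(=O)O` keeps the free acid of compound 2 and changes only the amide: morpholin-4-yl in place of dimethylamino on a carbonyl carbon. Within the data shown here, no measured pair shows such a step here, so no direction can be drawn from the data. In this assay the step from compound 2 to compound 3 is expected to be a 1.1-fold higher number from compound 2 to compound 3 (0.05 log units; within the scatter), which is no change beyond the usual scatter. Compound 3 is therefore expected to give 10 uM, with a likely range from 4 uM to 25 uM.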

Compound 3, concentration for 50% inhibition: 24 uM
For compound 3 the middle estimate is 2.4-fold (0.38 log units) below the measured one; low and high end bracket the measured number.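

In this assay, the amide amine now has a measurable effect on this series: morpholin-4-yl in place of dimethylamino on a carbonyl carbon gives a 2.7-fold higher number from compound 2 to compound 3 (0.43 log units; beyond the scatter). Within the data shown here, this is the first change here that can be read in one place, and because a higher number stands for weaker inhibition, the morpholine amide is the weaker of the two, though only by a small margin. Compound 1 gives only a limit of the assay and not a number: the limit of > 40 uM in this assay, at which 1 of the 3 values shown sits.

Compound 3 also links compound 1 to the free acid, with hydrogen in place of ethyl on an oxygen next to a carbonyl group giving an at least 1.6-fold lower number from compound 1 to compound 3 (0.22 log units; that floor lies within the scatter), but that floor lies within the scatter, so this step alone does not show that the free acid is better than the ethyl ester.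

With only two amines on this carbonyl, the compounds shown cannot separate the effect of the ring from that of its oxygen, which piperidin-1-yl, with a carbon in that place, could address. Diethylamino would likewise test whether longer chains on the amide nitrogen follow morpholin-4-yl or dimethylamino.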